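Methoxy position on the aryl ring in the acid series

A few compounds are considered here, and "the series" means these few. Any claim that something is new, unique, unknown or untested is made for them only; others in the source may bear on it.

Compound 2 `COc1ccccc1-c1nc(C)c(COc2ccc(C(=O)O)cc2)o1` gives in an assay on cells for antagonist activity at vitamin D3 receptor (Homo sapiens), read by a luciferase reporter (a lower number here means a stronger inhibitor, a higher number a weaker inhibitor), only a limit, > 80000 nM, not a number, and so stands at the weak end of what has been measured; this is the limit of > 80000 nM in this assay, at which 1 of the 2 values shown sits. Compound 1 `COC(=O)c1ccc(OCc2oc(-c3cccc(OC)c3)nc2C)cc1`, the methyl ester, gives 8890 nM in this assay. The change to compound 3 `COc1cccc(-c2nc(C)c(COc3ccc(C(=O)O)cc3)o2)c1` is 3-methoxyphenyl in place of 2-methoxyphenyl on an aromatic carbon. Among the compounds with values here, no measured step covers this change. A gain beyond the scatter is expected, because compound 1 carrying the same 3-methoxyphenyl gives 8890 nM. Compound 3 is estimated at 20000 nM, between 5000 nM and 80000 nM, an expected step of an at least 4.0-fold lower number from compound 2 to compound 3 (0.60 log units; beyond the scatter).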

Compound 3, half-maximal inhibitory concentration: > 80000 nM
Compound 3 was reported as a limit (the forecaster's own chance of this, stated with the estimate: 35%); at least 4.0-fold (0.60 log units) between middle value and limit.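

With 3-methoxyphenyl held fixed, hydrogen in place of methyl on an oxygen next to a carbonyl group gives an at least 8.9-fold higher number from compound 1 to compound 3 (0.95 log units; beyond the scatter) in this assay. Compound 3 gives only a limit, not a number, and so does compound 2, so the step between 2-methoxyphenyl and 3-methoxyphenyl in the acid series cannot be read: the limit of > 80000 nM in this assay, at which 2 of the 3 values shown sit.

Open, from the compounds shown here alone, is whether the methyl ester carrying 2-methoxyphenyl differs from compound 1. Also open, going by these compounds, is whether an amide or a longer chain in place of the carboxylic acid gives a readable value.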